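This account rests on a few compounds, and the source may have more. Where it says the series, first, only, none or still open, it means among the compounds named here.

Measured compounds in a functional assay on MCF7 cells (Homo sapiens) for antiproliferative activity, read by sulforhodamine B assay, with a stated time of 48 h; a lower number here means a stronger inhibitor of growth, a higher number a weaker inhibitor of growth:
compound 1, `O=C(NCc1cn(Cc2ccc(Cl)cc2)nn1)c1cn(-c2ccccc2)nc1-c1ccc(F)cc1`, gives 130 nM.
compound 2, `O=C(NCc1cn(Cc2ccc(Cl)cc2)nn1)c1cn(-c2ccccc2)nc1-c1ccc(Cl)cc1`, gives 28800 nM.
compound 3, `COc1ccc(-c2nn(-c3ccccc3)cc2C(=O)NCc2cn(Cc3ccc(Cl)cc3)nn2)cc1`, gives 2900 nM.

Compound 3 stands second highest of the three in this assay. Its nearest neighbour is compound 2: a 9.9-fold lower number from compound 2 to compound 3 (1.00 log units; beyond the scatter). Its furthest is compound 1: a 22-fold higher number from compound 1 to compound 3 (1.35 log units; beyond the scatter). The third step, a 220-fold higher number from compound 1 to compound 2 (2.35 log units; beyond the scatter), is the largest of the set. All three steps concern the single substituent on the aryl ring attached to the shared core.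

Compound 4, `COc1ccc(-c2nn(-c3ccccc3)cc2C(=O)NCc2cn(Cc3cc(OC)c(OC)c(OC)c3)nn2)cc1`, differs from compound 3 by 3,4,5-trimethoxyphenyl in place of 4-chlorophenyl on a saturated chain carbon bound to an aromatic nitrogen. For the measured compounds named here, no measured step touches this place; the three large steps above change a different group and give no guide to the size or direction of a change here. The expectation for compound 4 therefore rests on the value of compound 3 alone, with a wide range: no step beyond the scatter is assumed, so no change at the digits printed from compound 3 to compound 4 (within the scatter) is the expected step. Compound 4 is thus estimated at 2900 nM in this assay, between 500 nM and 17000 nM.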

Compound 4, concentration for 50% growth inhibition: 7600 nM
Compound 4: the middle estimate sits 2.6-fold (0.42 log units) below what was measured; low and high end bracket the measured number.
By their numbers in this assay, from the lowest: compound 1; then compound 3; then compound 4; then compound 2.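

In this assay, for the compounds shown here, a 2.6-fold higher number from compound 3 to compound 4 (0.42 log units; beyond the scatter) gives the first reading at this place, with 3,4,5-trimethoxyphenyl in place of 4-chlorophenyl on a saturated chain carbon bound to an aromatic nitrogen. The place is therefore not silent, although this exchange, which adds three methoxy groups and removes the chlorine, is a modest step and leaves compound 4 with a number in the same micromolar range as compound 3. No measurement available here accounts for the direction or the size of this step.

Going by these compounds, whether the same exchange would shift the fluoro-bearing compound 1, at 130 nM, by a similar step remains open. Also open, on these data alone, is how this place would respond to an unsubstituted phenyl, an amine or a carboxylic acid, or to a longer chain.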